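A few compounds are considered here, and "the series" means these few. Any claim that something is new, unique, unknown or untested is made for them only; others in the source may bear on it.

Working notes on the series. In an ADME assay on isolated protein for pharmacokinetics, with UDP-glucuronosyltransferase 1A9 (Homo sapiens) as the target, read by LC-MS, with a stated time of 60 min, at 37 degrees C, tested at 1 uM, in the presence of a further agent that is not named here (on this read-out lower numbers stand for a shorter-lived compound and higher numbers for a longer-lived compound), compound 2 `NS(=O)(=O)CC(=O)NCCSc1nonc1/C(=N/O)Nc1cccc(Br)c1` gives 0.955 h, the only number shown. Compound 1 `NS(=O)(=O)CC(=O)NCCSc1nonc1/C(=N/O)Nc1ccc(F)c(C(F)F)c1` stands at a limit of this assay, not a number: compound 1 gives > 3 h (the limit of > 3 h in this assay, at which 1 of the 2 values shown sits). Among the compounds with values here, the one measured step, an at least 3.1-fold lower number from compound 1 to compound 2 (0.49 log units; beyond the scatter), is at least modest and runs downward. Compound 3 `N#Cc1cc(N/C(=N\O)c2nonc2SCCNC(=O)CS(N)(=O)=O)ccc1F` differs from compound 2 by 3-cyano-4-fluorophenyl in place of 3-bromophenyl on an amine nitrogen. Within the data shown here, no measured step covers this change, yet the entering group brings compound 3 nearer to compound 1 than compound 2 is, so a move back upward is expected. Compound 3 is expected to give 2 h (range 0.8 h to 4.5 h), meaning a 2.1-fold higher number from compound 2 to compound 3 (0.32 log units; beyond the scatter).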

Compound 3, half-life: > 3 h
Compound 3: a limit, no number; the forecaster's own chance of this, stated with the estimate: 30%; middle value at least 1.5-fold (0.17 log units) away from the limit.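

In this assay, 3-cyano-4-fluorophenyl in place of 3-bromophenyl on an amine nitrogen gives an at least 3.1-fold higher number from compound 2 to compound 3 (0.49 log units; beyond the scatter) and so shows a rise beyond the scatter at this position. Compound 3 gives a limit, not a number, and reaches the same limit as compound 1: the limit of > 3 h in this assay, at which 2 of the 3 values shown sit. The step between compound 1 and compound 3, cyano in place of difluoromethyl on an aromatic carbon, cannot be read from two limits.

On these data alone, how far compound 1 and compound 3 lie past the limit stays open. Also open, as far as these compounds go, is whether a 3-chloro-4-fluorophenyl or plain 4-fluorophenyl group on this amine nitrogen would reach the same limit.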